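From compound 2 to compound 4: working notes

The source may report more compounds than this note shows. Statements on the series, on what has been measured and on what is new or still open speak of the compounds shown alone.

Three compounds of the series have a reading in an ADME assay on HepG2 cells (Homo sapiens) for cytotoxicity, read by MTT assay, with a stated time of 24 h; on this read-out higher numbers stand for lower toxicity in this test and lower numbers for higher toxicity in this test. For the measured compounds named here, compound 1 (`CC1Cn2c(nc([N+](=O)[O-])c2Br)O1`) gives 20100 nM, the only exact number among them. Compound 2 (`CC1Cn2c(nc([N+](=O)[O-])c2-c2ccc(Cl)cc2)O1`) reads > 140000 nM, which is a limit of the assay and not a number. Compound 3 (`CC1Cn2c(nc([N+](=O)[O-])c2-c2cccc(C#N)c2)O1`) reads > 500000 nM, which is also a limit. Compound 2 therefore has no exact place on the scale, though its limit puts it on the less toxic side of compound 1.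

Compound 4 (`CC1Cn2c(nc([N+](=O)[O-])c2-c2ccc(OC(F)(F)F)cc2)O1`) carries trifluoromethoxy in place of chloro on an aromatic carbon, para to a large group: trifluoromethoxy in place of chloro on an aromatic carbon. The rest of compound 2 is kept. Going by the values given here, no measured pair isolates a change of this kind, so the expectation rests on the readings of compound 2 and compound 3, neither of which is an exact number. In this assay the estimated step that the limit leaves unreadable from compound 2 to compound 4 is expected to stay within the usual scatter, and the reading may well be a limit again. For compound 4 the expected value is 150000 nM, with an estimated range from 50000 nM to 500000 nM.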

Compound 4, half-maximal cytotoxic concentration: > 184000 nM
Compound 4 was reported as a limit (the forecaster's own chance of this, stated with the estimate: 60%); middle value at least 1.2-fold (0.08 log units) from the limit.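

In this assay compound 4 reads > 184000 nM, which is a limit and not a number. For the compounds shown here, compound 2 reads > 140000 nM, also a limit, so no step from one to the other can be read. The compounds shown leave open whether trifluoromethoxy in place of chloro on an aromatic carbon changes the reading at all.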